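Swapping Bromo for Methyl on a Weak Antiproliferative Thiourea

This account rests on a few compounds, and the source may have more. Where it says the series, first, only, none or still open, it means among the compounds named here.

Of the compounds shown here, two built on one shared core have been tested in a functional assay on HeLa cells (Homo sapiens) for antiproliferative activity, with a stated time of 24 h; on this read-out higher numbers stand for weaker inhibition and lower numbers for stronger inhibition. Compound 1 `Cc1ccccc1NC(=S)N1CCc2c(sc(NC(=O)c3ccccc3C(F)(F)F)c2C(N)=O)C1` gives 47000 nM in this assay. Compound 2 `Cc1ccccc1C(=O)Nc1sc2c(c1C(N)=O)CCN(C(=S)Nc1ccccc1Br)C2` reaches only the limit of the assay, > 50000 nM, so its value is a bound rather than a number; it stands at the limit of > 50000 nM in this assay, at which 1 of the 2 values shown sits. Compound 3 `Cc1ccccc1NC(=S)N1CCc2c(sc(NC(=O)c3ccccc3C)c2C(N)=O)C1` is the untested partner and differs from compound 2 by methyl in place of bromo on an aromatic carbon. Among the measured compounds shown here, no measured pair shows this exact change, so the expected step of a number no higher from compound 2 to compound 3 (the limit leaves the size open) is small, no larger than the scatter, and in no set direction. Compound 3 is expected to give about 50000 nM, in a range from 20000 nM to 120000 nM.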

Compound 3, half-maximal inhibitory concentration: > 50000 nM
Compound 3 ended at the assay's limit (the forecaster's own chance of this, stated with the estimate: 50%); the middle value lies on the limit itself.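

Methyl in place of trifluoromethyl on an aromatic carbon gives an at least 1.0-fold higher number from compound 1 to compound 3 (0.02 log units; that floor lies within the scatter) in this assay, so this swap brings no gain in inhibition. Compound 2 and compound 3 both carry limits of the assay, so the step for methyl in place of bromo cannot be read. With 2-bromophenyl or 2-methylphenyl in this place, the result stays at that limit: the limit of > 50000 nM in this assay, at which 2 of the 3 values shown sit.

As far as these compounds go, whether an amine or a carboxylic acid on this aromatic carbon would give a readable number stays open. From the compounds shown here alone, how far compound 3 lies beyond its limit also stays open.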